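The source may hold more compounds than are shown below. What is called first, only, known or untested is meant among the compounds shown, and "the series" means these compounds.

For the measured compounds named here, in a functional assay on MDA-MB-435 cells (Homo sapiens) for inhibition, read by sulforhodamine B assay, with a stated time of 48 h (on this read-out lower numbers stand for stronger inhibition of growth and higher numbers for weaker inhibition of growth), compound 1 (`N#Cc1c(-c2nnc(-c3ccccc3)c3nn(-c4ccccc4)cc23)nn(-c2ccccc2)c1-c1ccccc1`) gives 31800 nM and compound 2 (`N#Cc1c(-c2nnc(-c3ccccc3)c3nn(-c4ccc(Cl)cc4)cc23)nn(-c2ccccc2)c1-c1ccccc1`) gives 23800 nM on the only two numbers so far. Compound 2 has the lower of these two numbers only nominally, as the two values lie within the scatter of each other and no order can be drawn between them. Going by the values given here, the single measured step, chloro in place of hydrogen on an aromatic carbon, reads a 1.3-fold lower number from compound 1 to compound 2 (0.13 log units; within the scatter) and is the only evidence bearing on the next substitution.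

Compound 3 (`Cc1ccc(-n2cc3c(-c4nn(-c5ccccc5)c(-c5ccccc5)c4C#N)nnc(-c4ccccc4)c3n2)cc1`) differs from compound 2 by methyl in place of chloro on an aromatic carbon, 4-chlorophenyl to 4-methylphenyl (methyl in place of chloro on an aromatic carbon). Among the compounds with values here, no measured compound carries methyl at this place, so the expectation rests on the small size of a 1.3-fold lower number from compound 1 to compound 2 (0.13 log units; within the scatter) alone. No step beyond the scatter is therefore expected in this assay and no direction can be argued. Compound 3 is estimated at 27000 nM (range 14000 nM to 50000 nM). This estimate means an expected 1.1-fold higher number from compound 2 to compound 3 (0.05 log units; within the scatter) for the substitution.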

Compound 3, concentration for 50% growth inhibition: 46300 nM
Estimate against measurement, compound 3: 1.7-fold (0.23 log units) below; the measured number falls inside the stated range.
By their numbers in this assay, from the lowest: compounds 2, 1 and 3 (each within the scatter of the next).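

In this assay, methyl in place of chloro gives a 1.9-fold higher number from compound 2 to compound 3 (0.29 log units; within the scatter), and methyl in place of hydrogen gives a 1.5-fold higher number from compound 1 to compound 3 (0.16 log units; within the scatter). With a carbon substituent now alongside hydrogen and chloro on the aromatic carbon para to a large group, all three pairs of compounds lie within the scatter, so hydrogen, chloro and methyl at this place do not separate the series in this read-out. No available measurement accounts for these values.

The compounds shown leave open whether a larger or chemically different group at this place, such as an amine, a carboxylic acid or a longer alkyl chain, would produce a step beyond the scatter. They also leave open how the growth-inhibition values respond to changes elsewhere, as the nitrile and the remaining phenyl groups stay the same in compound 1, compound 2 and compound 3.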